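Hydroxymethyl in place of fluoromethyl on the side chain

This account rests on a few compounds, and the source may have more. Where it says the series, first, only, none or still open, it means among the compounds named here.

Compound 3 `COc1cc(C(c2ccc(O)c(OC)c2)[C@@H](C)[C@@H](C)CF)ccc1O` gives 42000 nM in a functional assay on HeLa cells (Homo sapiens) for cytotoxicity, read by WST assay, with a stated time of 48 h; a higher number here means a weaker inhibitor, a lower number a stronger inhibitor. Compound 1 `COC[C@H](C)[C@H](C)C(c1ccc(O)c(OC)c1)c1ccc(O)c(OC)c1` gives 72000 nM; the step of a 1.7-fold lower number from compound 1 to compound 3 (0.23 log units; within the scatter) lies within the scatter, so compound 3 and compound 1 cannot be separated, although compound 3 carries the lowest of the two numbers read. For compound 2 `COc1cc(C(c2ccc(O)c(OC)c2)[C@H](C)[C@H](C)CO)ccc1O` only a limit is reported in this assay, > 100000 nM, namely (the limit of > 100000 nM in this assay, at which 1 of the 3 values shown sits). The steps of an at least 1.3-fold higher number from compound 1 to compound 2 (0.14 log units; that floor lies within the scatter) and an at least 2.3-fold lower number from compound 2 to compound 3 (0.37 log units; beyond the scatter) are therefore floors, the second of them beyond the scatter.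

Compound 4 `COc1cc(C(c2ccc(O)c(OC)c2)[C@@H](CO)C(C)C)ccc1O` differs from compound 3 as follows: 1-(hydroxymethyl)-2-methylpropyl in place of 2-(fluoromethyl)-1-methylpropyl on a saturated chain carbon bound to two aromatic carbons. The step that bears on it is the reversal of an at least 2.3-fold lower number from compound 2 to compound 3 (0.37 log units; beyond the scatter), in which the 2-(hydroxymethyl)-1-methylpropyl group on a saturated chain carbon bound to two aromatic carbons gave the higher number. Among the measured compounds shown here, compound 4 likewise carries a hydroxymethyl group on that carbon, though arranged as 1-(hydroxymethyl)-2-methylpropyl, for which compound 2 is the only comparison. The step of a 2.4-fold higher number from compound 3 to compound 4 (0.38 log units; beyond the scatter) is therefore expected to run toward a weaker inhibitor. Compound 4 is estimated at 100000 nM, with a range from 40000 nM to 300000 nM, and a limit rather than a number is quite possible.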

Compound 4, half-maximal inhibitory concentration: > 100000 nM
Compound 4 was reported as a limit; the forecaster's own chance of this, stated with the estimate: 50%; the middle value sits exactly at the limit.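

In this assay, 1-(hydroxymethyl)-2-methylpropyl in place of 2-(fluoromethyl)-1-methylpropyl on a saturated chain carbon bound to two aromatic carbons gives a step beyond the scatter (an at least 2.3-fold higher number from compound 3 to compound 4 (0.37 log units; beyond the scatter)), so the higher number now holds for a second hydroxymethyl arrangement, not only for that of compound 2. Against the 2-(methoxymethyl)-1-methylpropyl group, the step is only a floor (an at least 1.3-fold higher number from compound 1 to compound 4 (0.14 log units; that floor lies within the scatter)), and it does not separate compound 4 from compound 1. The step between the two hydroxymethyl arrangements cannot be read, since compound 2 and compound 4 are both limits: the limit of > 100000 nM in this assay, at which 2 of the 4 values shown sit.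

On these data alone, how far either hydroxymethyl arrangement lies above the limit remains open. Also open, as far as these compounds go, is how an amine or a carboxylic acid at the chain end, or a longer chain, would read in this assay.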